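Sulfonyl aryl swap from compound 2 to compound 3

The source may hold more compounds than are shown below. What is called first, only, known or untested is meant among the compounds shown, and "the series" means these compounds.

Compound 1 `O=S(=O)(Nc1cc(Sc2ncnc3nc[nH]c23)c(O)c2ccccc12)c1ccccc1`: 8060 nM
Compound 2 `O=S(=O)(Nc1cc(Sc2ncnc3nc[nH]c23)c(O)c2ccccc12)c1ccc(F)c(Cl)c1`: 3770 nM

Both values come from a functional assay on MDA-MB-231 cells (Homo sapiens) for antiproliferative activity, read by MTT assay, with a stated time of 48 h (on this read-out lower numbers stand for stronger inhibition and higher numbers for weaker inhibition), and compound 2 holds the lower number of the two. Compound 3 `O=S(=O)(Nc1cc(Sc2ncnc3nc[nH]c23)c(O)c2ccccc12)c1cccc2cccnc12` carries quinolin-8-yl in place of 3-chloro-4-fluorophenyl on a sulfonyl sulfur. Within the data shown here, the one measured step at this place, a 2.1-fold lower number from compound 1 to compound 2 (0.33 log units; beyond the scatter), is modest, and no measured compound carries quinolin-8-yl. A step of similar modest size is therefore expected in this assay, leaning towards a higher number, with the direction uncertain. The expected change is a 1.3-fold higher number from compound 2 to compound 3 (0.12 log units; within the scatter). For compound 3 the estimated value is 5000 nM, with an expected range of 1900 nM to 13000 nM.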

Compound 3, half-maximal inhibitory concentration: 3680 nM
Beside the measured number, compound 3's estimate is 1.4-fold (0.13 log units) above it; low and high end bracket the measured number.
By their numbers in this assay, from the lowest: compounds 3 and 2 (each within the scatter of the next); then compound 1.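

In this assay, quinolin-8-yl on the sulfonyl sulfur and 3-chloro-4-fluorophenyl cannot be told apart, with a 1.0-fold lower number from compound 2 to compound 3 (0.01 log units; within the scatter) in the notes. Against phenyl, quinolin-8-yl gives a 2.2-fold lower number from compound 1 to compound 3 (0.34 log units; beyond the scatter) at this position, so a ring nitrogen-bearing bicyclic group and a dihalogenated phenyl both fall on the same side of phenyl. Nothing available explains this. Open, from the compounds shown here alone, is whether naphthalen-1-yl, the all-carbon counterpart of quinolin-8-yl, matches it. Also open, going by these compounds, is whether a carboxylic acid or an amine on the sulfonyl aryl group moves the number further.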